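A few compounds are considered here, and "the series" means these few. Any claim that something is new, unique, unknown or untested is made for them only; others in the source may bear on it.

Among the measured compounds shown here, in a functional assay on A-375 cells (Homo sapiens) for inhibition, read by CCK-8 assay, with a stated time of 72 h (on this read-out lower numbers stand for stronger inhibition and higher numbers for weaker inhibition), compound 3 `O=C(NO)c1ccc(CNC(=O)c2n[nH]cc2NC(=O)c2c(Cl)cccc2Cl)cc1` gives 5050 nM, the highest of the three numbers so far. Compound 1 `Nc1ccccc1NC(=O)c1ccc(CNC(=O)c2n[nH]cc2NC(=O)c2ccccc2Cl)cc1` gives 2110 nM and compound 2 `Nc1ccccc1NC(=O)c1ccc(CNC(=O)c2n[nH]cc2NC(=O)c2ccccc2)cc1` gives 1590 nM. Both carry the (2-aminophenyl)carbamoyl group, and both lie beyond the scatter below compound 3.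

Compound 4 `Nc1ccccc1NC(=O)c1ccc(CNC(=O)c2n[nH]cc2NC(=O)c2c(Cl)cccc2Cl)cc1` keeps the rest of compound 3 and changes one group: 2-aminophenyl in place of hydroxy on an amide-type nitrogen. For the measured compounds named here, no measured step covers this change directly. Going by the values given here, the only measured step, a 1.3-fold lower number from compound 1 to compound 2 (0.12 log units; within the scatter), is hydrogen in place of chloro on an aromatic carbon and stays within the scatter. It gives a weak hint that the chloro substitution moves the number little, although the pattern in compound 3 has not been measured with the (2-aminophenyl)carbamoyl group.

Compound 4 is therefore expected to sit close to compound 1 at 2110 nM, with a lower number than compound 3. The expected size of the change is a 2.1-fold lower number from compound 3 to compound 4 (0.32 log units; beyond the scatter), a modest step near the edge of the scatter. For compound 4 the estimated value is 2400 nM, with an expected range from 1100 nM to 5500 nM.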

Compound 4, half-maximal inhibitory concentration: 1200 nM
Beside the measured number, compound 4's estimate is 2.0-fold (0.30 log units) above it; the range from low to high includes it.
By their numbers in this assay, from the lowest: compounds 4, 2 and 1 (each within the scatter of the next); then compound 3.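

In this assay, among the compounds shown here, the change from hydroxy to 2-aminophenyl on the amide-type nitrogen gives the first direct comparison of the two groups with the rest of the structure held constant (a 4.2-fold lower number from compound 3 to compound 4 (0.62 log units; beyond the scatter)), and the step lies beyond the scatter. With the (2-aminophenyl)carbamoyl group held constant, the chloro pattern stays within the scatter, both for 2,6-dichlorophenyl in place of phenyl (a 1.3-fold lower number from compound 2 to compound 4 (0.12 log units; within the scatter)) and for chloro in place of hydrogen (a 1.8-fold lower number from compound 1 to compound 4 (0.25 log units; within the scatter)). Nothing available explains these results.

For the compounds shown here, whether the chloro pattern also stays within the scatter with the hydroxycarbamoyl group remains open, with compound 3 as the only example carrying that group. Also open, going by these compounds, is how a carboxylic acid in place of hydroxycarbamoyl, or 2-hydroxyphenyl in place of 2-aminophenyl, would read.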